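The source may report more compounds than this note shows. Statements on the series, on what has been measured and on what is new or still open speak of the compounds shown alone.

Measured compounds in a functional assay for inhibition, tested at 80 ug/mL; on this read-out lower numbers stand for a weaker effect and higher numbers for a stronger effect at the one concentration tested:
compound 1 `Cc1cc(O)c(C(C)C)cc1-c1cc(-c2ccccc2)c(C#N)c(=O)[nH]1` gives 58%
compound 2 `Cc1cc(O)c(C(C)C)cc1-c1cc(-c2cccs2)c(C#N)c(=O)[nH]1` gives 63%
compound 3 `Cc1cc(O)c(C(C)C)cc1-c1cc(-c2ccco2)c(C#N)c(=O)[nH]1` gives 64%

Compound 3 holds the highest of the three numbers, yet it is not set apart: compound 2 lies a number 1 percentage points higher from compound 2 to compound 3 (within the scatter) and compound 1 lies a number 6 percentage points higher from compound 1 to compound 3 (within the scatter), both inside the scatter, so the three measured compounds read as one level in this assay.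

Compound 4 `Cc1cc(O)c(C(C)C)cc1-c1cc(-c2ccc(N(C)C)cc2)c(C#N)c(=O)[nH]1` remains to be measured in this assay. Its difference from compound 3 is 4-(dimethylamino)phenyl in place of furan-2-yl on an aromatic carbon. For the measured compounds named here, the steps that bear on this exchange are the ones in which the group on that aromatic carbon was varied: a number 5 percentage points higher from compound 1 to compound 2 (within the scatter), a number 6 percentage points higher from compound 1 to compound 3 (within the scatter) and a number 1 percentage points higher from compound 2 to compound 3 (within the scatter). Each stayed within the scatter, so exchanging phenyl, thiophen-2-yl and furan-2-yl on this carbon has not moved the number. The entering 4-(dimethylamino)phenyl is closest in kind to the phenyl of compound 1, which gave 58%. A fourth group on the same carbon is therefore expected to give no step beyond the scatter, the expected step being a number 4 percentage points lower from compound 3 to compound 4 (within the scatter). Compound 4 is estimated at 60%, with a range from 42% to 76%.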

Compound 4, a percentage reported as inhibition, at one concentration (the size of the read-out at that concentration, not a potency): 66.5%
Estimate against measurement, compound 4: 6.5 percentage points below; the range from low to high includes it.
By their numbers in this assay, from the lowest: compounds 1, 2, 3 and 4 (each within the scatter of the next).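

In this assay, putting 4-(dimethylamino)phenyl in place of furan-2-yl on the aromatic carbon opposite the ring nitrogen gives a number 2.5 percentage points higher from compound 3 to compound 4 (within the scatter), and putting it in place of thiophen-2-yl gives a number 3.5 percentage points higher from compound 2 to compound 4 (within the scatter). Dimethylamino in place of hydrogen on the phenyl gives a number 8.5 percentage points higher from compound 1 to compound 4 (within the scatter), so this position now holds a substituted six-membered aromatic ring as well as the unsubstituted phenyl and the two five-membered aromatic rings, with every step among these four compounds staying within the scatter. Nothing available here accounts for this flat response to the group on this carbon.

Still open, going by these compounds, is whether a non-aromatic group on this carbon, such as cyclohexyl or a longer alkyl chain, or a carboxylic acid on the phenyl in place of dimethylamino, would leave the number at this level. Also open, on these data alone, is whether the level would hold if the nitrile, the hydroxyl or the isopropyl of the shared core were exchanged, and how these compounds would compare at other concentrations in this assay.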